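Cytotoxicity notes: carbamate and urea analogues of one core

The source may hold more compounds than are shown below. What is called first, only, known or untested is meant among the compounds shown, and "the series" means these compounds.

Measured so far:
compound 1 `CN(C)CCCCNC(=O)Nc1ccc(CN2N=C(c3ccc(F)cc3)C3C=CC=CC3C2=O)cc1`, 46600 nM
compound 2 `CN(C)CCCCOC(=O)Nc1ccc(Cn2nc(-c3cccnc3)c3ccccc3c2=O)cc1`, 68000 nM

In an ADME assay on Huh-7 cells (Homo sapiens) for cytotoxicity, read by MTT assay, with a stated time of 48 h (on this read-out lower numbers stand for higher toxicity in this test and higher numbers for lower toxicity in this test), compound 1 gives 46600 nM and compound 2 gives 68000 nM; the two numbers lie within the scatter of each other, so neither compound is set apart in this assay. Compound 3 `COc1ccccc1-c1nn(Cc2ccc(NC(=O)OCCCCN(C)C)cc2)c(=O)c2ccccc12` is not yet measured. It differs from compound 2 by 2-methoxyphenyl in place of pyridin-3-yl on an aromatic carbon. Within the data shown here, no measured pair shows the effect of this change. The number for compound 3 is expected close to that of compound 2, with a step of a 1.2-fold lower number from compound 2 to compound 3 (0.09 log units; within the scatter) that stays within the scatter. Compound 3 is estimated at 55000 nM, in the range 25000 nM to 120000 nM.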

Compound 3, half-maximal cytotoxic concentration: 44800 nM
Compound 3: the middle estimate sits 1.2-fold (0.09 log units) above what was measured, within the range that was stated.
By their numbers in this assay, from the lowest: compounds 3, 1 and 2 (each within the scatter of the next).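

In this assay, this aromatic carbon next to the ring nitrogen now has a measured change: 2-methoxyphenyl in place of pyridin-3-yl gives a 1.5-fold lower number from compound 2 to compound 3 (0.18 log units; within the scatter). Exchanging the pyridine ring for a carbon-only aromatic ring with 8 heavy atoms in place of 6 therefore produces no step beyond the scatter at this position. Nothing available explains the size of this step.

On these data alone, whether an amine or a carboxylic acid on this aromatic carbon would also stay within the scatter remains open. The urea of compound 1 differs from compound 2 in more than one place, so the effect of that link cannot be read.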